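Swapping the ring on a glyoxylamide-type amide nitrogen

A few compounds are considered here, and "the series" means these few. Any claim that something is new, unique, unknown or untested is made for them only; others in the source may bear on it.

Compound 1 (`COc1ncc(NC(=O)C(=O)c2cn(C(C)C)c3ccccc23)cn1`): 171 nM
Compound 2 (`COCCn1cc(C(=O)C(=O)Nc2ccc(OCC(=O)O)nc2)c2ccccc21`): > 10000 nM (a limit)
Compound 3 (`COc1nsc(NC(=O)C(=O)c2cn(C(C)C)c3ccccc23)n1`): not yet measured

For the measured compounds named here, in a functional assay on FaDu cells (Homo sapiens) for cytotoxicity, read by MTT assay, with a stated time of 72 h (on this read-out lower numbers stand for higher toxicity in this test and higher numbers for lower toxicity in this test), compound 1 gives 171 nM, the only true number so far. Compound 2 gives > 10000 nM, which is a limit of the assay and not a number.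

Compound 3 keeps the core of compound 1 but carries 3-methoxy-1,2,4-thiadiazol-5-yl in place of 2-methoxypyrimidin-5-yl on an amide-type nitrogen. Going by the values given here, no measured step links two closely matched compounds here, so the expectation rests on the structural change alone. One aromatic ring replaces another and the methoxy group stays, so only a moderate move towards a higher number in this assay is expected. The estimated change is a 2.3-fold higher number from compound 1 to compound 3 (0.37 log units; beyond the scatter), and it may prove no larger than the usual scatter. For compound 3 the expected value is 400 nM, with an estimated range from 90 nM to 2500 nM.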

Compound 3, concentration lethal to 50% of the cells: 10400 nM
The estimate for compound 3 lay 26-fold (1.41 log units) below the measured number; the measured number lies above the stated range.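

With the core and the methoxy group unchanged, the ring on the amide-type nitrogen proves to matter greatly in this assay: 3-methoxy-1,2,4-thiadiazol-5-yl in place of 2-methoxypyrimidin-5-yl gives a 61-fold higher number from compound 1 to compound 3 (1.78 log units; beyond the scatter). A single exchange of one aromatic ring for another is therefore enough to remove most of the toxicity seen in this test. Compound 2 differs from compound 1 in more than one place, so it offers no clean comparison, and its value is a limit of the assay and not a number: the limit of > 10000 nM in this assay, at which 1 of the 3 values shown sits.

This one swap changes ring size, the number of hetero atoms and the presence of sulfur together, so the compounds shown cannot say which of these matters. Also open, from the compounds shown here alone, is what an amine in place of the methoxy group, or a plain phenyl ring on the amide-type nitrogen, would do.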